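The source may hold more compounds than are shown below. What is called first, only, known or untested is meant among the compounds shown, and "the series" means these compounds.

Three compounds have been measured in a functional assay on SK-MEL-2 cells (Homo sapiens) for cytotoxicity, read by sulforhodamine B assay, with a stated time of 48 h, tested at 100 nM; on this read-out higher numbers stand for a weaker effect at the one concentration tested and lower numbers for a stronger effect:

compound 1 `COc1cc(C)cc(-c2c(-c3ccnc(-c4ccc(C(C)=O)cc4)c3)cnn2CC#N)c1` gives 103%
compound 2 `COc1cc(C)cc(-c2nn(CC#N)cc2-c2ccc(-c3cccc(C(C)=O)c3)nc2)c1` gives 88%
compound 3 `Cc1cc(O)cc(-c2nn(CC#N)cc2-c2ccnc(-c3ccc(N(C)C)cc3)c2)c1` gives 112%

Compound 1 stands second highest of the three numbers. Its nearest neighbour is compound 3, whose value lies higher but within the usual scatter, so the two cannot be told apart. Compound 2 gives the lowest number, and its distance from compound 1 lies beyond the scatter, which is the only difference among the three that can be trusted. Among the measured compounds shown here, none of the three differs from another in a single place, so no step between measured compounds is available.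

Compound 4 `COc1cc(C)cc(-c2c(-c3ccnc(-c4ccc(N(C)C)cc4)c3)cnn2CC#N)c1` is the next compound to be measured in this assay. It differs from compound 1 in one place: dimethylamino in place of acetyl on an aromatic carbon. Compound 3 carries the same dimethylamino-bearing ring and gives 112%, a number close to compound 1. On that basis the step of a number 2 percentage points higher from compound 1 to compound 4 (within the scatter) is expected to be small, with no change beyond the scatter. Compound 4 is therefore estimated at 105%, within a range from 92% to 118%.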

Compound 4, a percentage reported as activity, at one concentration (the size of the read-out at that concentration, not a potency): 14%
Compound 4: the middle estimate sits 91 percentage points above what was measured, and the stated range ends above it.
By their numbers in this assay, from the lowest: compound 4; then compound 2; then compounds 1 and 3 (each within the scatter of the next).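

Dimethylamino in place of acetyl gives a number 89 percentage points lower from compound 1 to compound 4 (beyond the scatter) in this assay, the first step among these compounds that can be read, and it shows that the read-out is highly sensitive to the group at this position, para to a large group. The two groups match in size by heavy-atom count and hydrogen-bond acceptors, so those counts do not separate compound 1 from compound 4. Compound 3 carries the same 4-(dimethylamino)phenyl group and gives 112%, but it differs from compound 4 in more than one place, so the two values cannot be tied to a single change.

No measurement here explains this step. The compounds shown leave open whether a primary amine, a methylamino group or a morpholine at this position would give a similar number, and so whether the nitrogen or its two methyl groups matter.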